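Changing the aromatic group on the amide nitrogen

The source may hold more compounds than are shown below. What is called first, only, known or untested is meant among the compounds shown, and "the series" means these compounds.

In a functional assay on A549 cells (Homo sapiens) for cytotoxicity, read by MTT assay, with a stated time of 72 h (a lower number here means a stronger inhibitor, a higher number a weaker inhibitor), three compounds sharing one core have been tested. Compound 1 `O=C(CN1CCN(c2nnc(Cc3ccccc3)c3ccccc23)CC1)Nc1ccc(F)c(C(F)(F)F)c1` gives 2480 nM. Compound 3 `O=C(CN1CCN(c2nnc(Cc3ccccc3)c3ccccc23)CC1)Nc1ccc(F)c(F)c1` gives 10100 nM, the higher of the two numbers available and so the weaker of the two inhibitors that could be quantified. Compound 2 `COc1ccc(NC(=O)CN2CCN(c3nnc(Cc4ccccc4)c4ccccc34)CC2)cc1OC` is reported as "not active" (no number reported), without a number.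

Compound 4 `Cc1cccc(Cl)c1NC(=O)CN1CCN(c2nnc(Cc3ccccc3)c3ccccc23)CC1` has not yet been measured. It differs from compound 3 as follows: 2-chloro-6-methylphenyl in place of 3,4-difluorophenyl on an amide-type nitrogen. The whole aromatic group on the amide-type nitrogen is therefore exchanged, with 2-chloro-6-methylphenyl in place of 3,4-difluorophenyl.

Going by the values given here, only one measured step bears on this group: a 4.1-fold higher number from compound 1 to compound 3 (0.61 log units; beyond the scatter), with fluoro in place of trifluoromethyl on an aromatic carbon. This step is modest but beyond the scatter. It shows that changes in this group can move the number, but it does not involve either the chloro or the methyl substituent, so it gives no firm direction. A step of similar size in either direction remains possible, and a result without a number, like that of compound 2, cannot be excluded. The expected central change is small, namely a 1.3-fold lower number from compound 3 to compound 4 (0.10 log units; within the scatter). For compound 4 the estimated value is 8000 nM, with an expected range from 2500 nM to 30000 nM.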

Compound 4, half-maximal inhibitory concentration: 7420 nM
The estimate for compound 4 lay 1.1-fold (0.03 log units) above the measured number; low and high end bracket the measured number.
By their numbers in this assay, from the lowest: compound 1; then compounds 4 and 3 (each within the scatter of the next).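

In this assay, exchanging the whole aromatic group on the amide-type nitrogen gives a 1.4-fold lower number from compound 3 to compound 4 (0.13 log units; within the scatter), so 2-chloro-6-methylphenyl and 3,4-difluorophenyl cannot be told apart here, although the two groups have no substituent in common. The position therefore tolerates this exchange without a measurable shift, and the step of a 3.0-fold higher number from compound 1 to compound 4 (0.48 log units; beyond the scatter), which is modest but beyond the scatter, shows that 4-fluoro-3-(trifluoromethyl)phenyl, not only its contrast with 3,4-difluorophenyl, sets compound 1 apart as the lowest number among the three quantified compounds, while compound 2, with no number, cannot be placed in this order. Nothing shown gives a measured reason for these numbers or for the separation of compound 1 from the other two.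

The compounds shown leave open whether the lower number of compound 1 follows from the trifluoromethyl group itself, since no other aromatic group here carries it, or from its combination with the fluoro substituent. They also leave open how a nitrile, a carboxylic acid or an amine on the aromatic group would read, and whether a saturated ring or an alkyl chain could stand in its place on the amide-type nitrogen.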